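Hydroxyphenyl change from compound 2 to compound 3

The source may report more compounds than this note shows. Statements on the series, on what has been measured and on what is new or still open speak of the compounds shown alone.

In an ADME assay on RAW264.7 cells (Mus musculus) for cytotoxicity, read by MTT assay (a lower number here means a stronger inhibitor, a higher number a weaker inhibitor), compound 1 (`CCCCCCCCCCOc1cccc(O)c1C(=O)/C=C/c1ccc(O)c(Cl)c1`) reads > 30000 nM as a limit of the assay, not a number. Compound 2 (`CCCCCCCCCCOc1cccc(O)c1C(=O)/C=C/c1cc(OC)c(O)c(OC)c1`) reads > 30000 nM and this too is only a limit. Among the compounds with values here, compound 2 therefore stands with the one other value shown, and the limit of > 30000 nM in this assay, at which 2 of the 2 values shown sit, is the whole picture so far. Compound 3 (`CCCCCCCCCCOc1cccc(O)c1C(=O)/C=C/c1cccc(O)c1`) differs from compound 2 by 3-hydroxyphenyl in place of 4-hydroxy-3,5-dimethoxyphenyl on a double-bonded chain carbon bound to a double-bonded chain carbon with 3-hydroxyphenyl in place of 4-hydroxy-3,5-dimethoxyphenyl on a double-bonded chain carbon bound to a double-bonded chain carbon. Within the data shown here, with a step that the two limits leave unreadable from compound 1 to compound 2 as the one measured change at this place, no step beyond the scatter is expected in this assay and a further limit is the likeliest reading. The expected step is a step that the limit leaves unreadable from compound 2 to compound 3 and remains an estimate only. The estimated value for compound 3 is 35000 nM within an expected range of 15000 nM to 60000 nM if a number is reported at all.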

Compound 3, half-maximal inhibitory concentration: > 30000 nM
Compound 3 was reported as a limit (the forecaster's own chance of this, stated with the estimate: 80%); the middle value lies beyond the limit too.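

In this assay, compound 3 gives > 30000 nM, a limit and not a number. No step among compound 1, compound 2 and compound 3 can be read: the limit of > 30000 nM in this assay, at which 3 of the 3 values shown sit.

Still open, as far as these compounds go, is whether the hydroxyphenyl changes separate these compounds at all in this assay, since none has a numerical value.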